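Swapping the halogenated phenyl on the shared core

This account rests on a few compounds, and the source may have more. Where it says the series, first, only, none or still open, it means among the compounds named here.

Of the compounds shown here, three have been measured in an assay on a protein complex for positive allosteric modulation of Neuronal acetylcholine receptor; alpha4/beta2 (Homo sapiens); on this read-out lower numbers stand for smaller maximal responses and higher numbers for larger maximal responses. Compound 1 `CN(Cc1cc(-c2ccccc2Cl)no1)C(=O)C1CCNCC1` gives 41%, compound 2 `Cc1c(-c2cc(-c3ccccc3)no2)cnn1C1CCNCC1` gives 31%, and compound 3 `Fc1ccc(Cl)c(-c2cc(-c3cnn(C4CCNCC4)c3)on2)c1` gives 29%. Compound 3 stands within the scatter of compound 2 and a step beyond the scatter apart from compound 1. Compound 4 `Clc1cccc(Cl)c1-c1cc(-c2cnn(C3CCNCC3)c2)on1` has not yet been measured in this assay; compared with compound 3 it differs by 2,6-dichlorophenyl in place of 2-chloro-5-fluorophenyl on an aromatic carbon. For the measured compounds named here, no step of this kind between two measured compounds is available, so the size of the step is estimated from the spread of the three numbers alone, and no change beyond the scatter is expected: a number 1 percentage points higher from compound 3 to compound 4 (within the scatter). Compound 4 is therefore estimated at 30%, with a range from 18% to 45%.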

Compound 4, largest response reached (reported as efficacy), in percent of the reference or control that the assay uses: 73%
Beside the measured number, compound 4's estimate is 43 percentage points below it; measured number above the stated range.
By their numbers in this assay, from the lowest: compounds 3, 2 and 1 (each within the scatter of the next, the first and the last beyond it); then compound 4.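

In this assay, putting 2,6-dichlorophenyl in place of 2-chloro-5-fluorophenyl on the aromatic carbon next to the ring nitrogen gives a number 44 percentage points higher from compound 3 to compound 4 (beyond the scatter). The earlier compounds shown here offered no step at this position; this one shows that the number responds strongly to how the phenyl group is substituted, even though both groups have the same count of heavy atoms. Nothing measured here bears on why the number moves so far.

The change removes the fluorine and adds a second chlorine at once, and the compounds shown do not separate the two. From the compounds shown here alone, whether 2,6-difluorophenyl or 2,6-dimethylphenyl would hold the higher number also stays open.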